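Swapping a chlorophenyl for a furan ring on a shared core

The compounds below may be only part of what the source reports. "The series", "measured", "known", "first", "only" and "open" are said of these compounds alone.

Compound 1 has the structure `Clc1ccc(-c2cc(-c3ccccc3)c3cc(Br)ccc3n2)cc1`. In a functional assay on Hep2C cells (Homo sapiens) for antiproliferative activity, read by MTT assay, with a stated time of 24 h (a lower number here means a stronger inhibitor, a higher number a weaker inhibitor), compound 1 gives 269000 nM, the higher of the two numbers recorded so far. Its nearest neighbour is compound 2, `Cc1ccc(-c2cc(-c3ccccc3)c3cc(Br)ccc3n2)cc1`, which differs from it only in carrying a methyl group where compound 1 carries a chlorine atom; in this assay compound 2 gives 175000 nM. The step from compound 1 to compound 2 is a 1.5-fold lower number from compound 1 to compound 2 (0.19 log units; within the scatter), so these two compounds cannot be told apart by this assay. A third member of the series, compound 3 with the structure `O=[N+]([O-])c1cccc(-c2cc(-c3ccccc3)c3cc(Br)ccc3n2)c1`, has in this assay the result "not determined" (no result reported), so it adds no number to compare with.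

Compound 4, `Brc1ccc2nc(-c3ccco3)cc(-c3ccccc3)c2c1`, is not yet measured. Compared with compound 1 the change is furan-2-yl in place of 4-chlorophenyl on an aromatic carbon. For the measured compounds named here, no measured step involves an exchange of this kind, so the only guide is the single step between compound 1 and compound 2, which stayed within the scatter. On that thin basis compound 4 is expected to give 240000 nM, with a range from 70000 nM to 800000 nM. The step from compound 1 to compound 4 is therefore estimated as a 1.1-fold lower number from compound 1 to compound 4 (0.05 log units; within the scatter), that is, no change beyond the scatter.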

Compound 4, half-maximal inhibitory concentration: 102000 nM
Compound 4: the middle estimate sits 2.4-fold (0.37 log units) above what was measured; the measured number falls inside the stated range.
By their numbers in this assay, from the lowest: compounds 4, 2 and 1 (each within the scatter of the next, the first and the last beyond it).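

In this assay, for the compounds shown here, the aromatic carbon next to the ring nitrogen responds to a change of ring type: furan-2-yl, a five-membered aromatic ring with 1 hetero atom, in place of 4-chlorophenyl gives a 2.6-fold lower number from compound 1 to compound 4 (0.42 log units; beyond the scatter) and this is the first step to lie beyond the scatter, though it is only modest. The same exchange made against 4-methylphenyl gives a 1.7-fold lower number from compound 2 to compound 4 (0.23 log units; within the scatter) and stays within the scatter, so the effect of bringing in the furan can be read only where 4-chlorophenyl is the group that leaves. No measurement shown here accounts for the difference, so the role of the ring oxygen or of the change in ring size remains unexplained.

A thiophene or an unsubstituted phenyl at this carbon would help show whether the oxygen atom itself matters or whether any other ring would do as well. Also open, from the compounds shown here alone, is how a ring with a basic amine, such as a piperazine, would behave here, and whether replacing the bromine or the phenyl group elsewhere on the shared core would move the number further.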